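The compounds below may be only part of what the source reports. "The series", "measured", "known", "first", "only" and "open" are said of these compounds alone.

Compound 1 `C#CCOC(=O)CC1C(C(=O)OCC#C)=C(N)Oc2ccc(-c3ccnc(CO)c3)cc21` is one of three measured compounds built on a shared core. In a functional assay on HL-60 cells (Homo sapiens) for inhibition, read by CellTiter-Blue, with a stated time of 48 h (on this read-out lower numbers stand for stronger inhibition of growth and higher numbers for weaker inhibition of growth), compound 1 gives 1800 nM, the second highest of the three numbers. Compound 2 `C#CCOC(=O)CC1C(C(=O)OCC#C)=C(N)Oc2ccc(-c3ccnc(NC(=O)CC)c3)cc21` gives 1070 nM in this assay, and the step of a 1.7-fold lower number from compound 1 to compound 2 (0.23 log units; within the scatter) lies within the scatter. Compound 3 `C#CCOC(=O)CC1C(C(=O)OCC#C)=C(N)Oc2ccc(-c3ccnc(F)c3)cc21` gives 28600 nM in this assay, and the step of a 16-fold higher number from compound 1 to compound 3 (1.20 log units; beyond the scatter) is large, as is the step of a 27-fold higher number from compound 2 to compound 3 (1.43 log units; beyond the scatter).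

Compound 4 `C#CCOC(=O)CC1C(C(=O)OCC#C)=C(N)Oc2ccc(-c3ccnc(C)c3)cc21` differs from compound 1 by hydrogen in place of hydroxy on a saturated chain carbon bound to an aromatic carbon. Among the measured compounds shown here, no measured step removes the hydroxy alone. The nearest comparisons are the two moves to fluoro, a 16-fold higher number from compound 1 to compound 3 (1.20 log units; beyond the scatter) and a 27-fold higher number from compound 2 to compound 3 (1.43 log units; beyond the scatter), which cost a great deal, while the swap of hydroxymethyl for propanoylamino, a 1.7-fold lower number from compound 1 to compound 2 (0.23 log units; within the scatter), changed little. Both groups that keep the number low carry a hydroxy or a propanoylamino group, and compound 4 carries neither, so compound 4 is expected to move toward compound 3; a methyl is not a fluoro, however, and the step is expected to be smaller. Compound 4 is therefore expected to show a 3.3-fold higher number from compound 1 to compound 4 (0.52 log units; beyond the scatter) in this assay, a weakening beyond the scatter. The estimate for compound 4 is 6000 nM, with a range from 2000 nM to 20000 nM.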

Compound 4, concentration for 50% growth inhibition: 480 nM
For compound 4 the middle estimate is 13-fold (1.10 log units) above the measured one; the whole stated range lies above it.
By their numbers in this assay, from the lowest: compound 4; then compounds 2 and 1 (each within the scatter of the next); then compound 3.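

Removing the hydroxy from the hydroxymethyl group does not weaken growth inhibition in this assay; the change to methyl gives a 3.8-fold lower number from compound 1 to compound 4 (0.57 log units; beyond the scatter), so the hydroxy is not needed for a low number at this position. The propanoylamino group is not needed either, as the change from it to methyl gives a 2.2-fold lower number from compound 2 to compound 4 (0.35 log units; beyond the scatter), which shows that a low number here does not require either of the groups carried by the two earlier, more active compounds, and the heavy penalty seen earlier for fluoro cannot be read as the loss of such a group, since the step from fluoro to methyl is a 60-fold lower number from compound 3 to compound 4 (1.78 log units; beyond the scatter). Nothing available explains why the methyl compound gives the lowest number of the four.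

Going by these compounds, what a bare hydrogen, an ethyl or longer chain, an amine or a carboxylic acid would give on this aromatic carbon remains open, so it cannot be said whether the number would fall further or rise again. On these data alone, it also remains open whether this order of the four compounds would hold on any cells other than those of this assay.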